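Swapping a naphthyl for a trifluoromethylbenzyl group

The compounds below may be only part of what the source reports. "The series", "measured", "known", "first", "only" and "open" are said of these compounds alone.

Three compounds have values in a functional assay on PC-9 cells (Homo sapiens) for inhibition, read by MTT assay, with a stated time of 72 h (a lower number here means a stronger inhibitor, a higher number a weaker inhibitor), so far:
- compound 1 `Cc1cc(Nc2cc(-c3ccccc3)[nH]n2)n2nc(SCc3ccc(F)cc3)nc2n1` gives 8110 nM
- compound 2 `Cc1cc(Nc2ccn(Cc3cccc4ccccc34)n2)n2nc(SCc3ccc(Br)cc3)nc2n1` gives 5660 nM
- compound 3 `C#CCSc1nc2nc(C)cc(Nc3cc(-c4ccccc4)[nH]n3)n2n1` gives > 50000 nM as a limit of the assay, not a number

The values of compound 2 and compound 1 lie within the usual scatter of each other, so the two count as level. Compound 4 `Cc1cc(Nc2ccn(Cc3ccc(C(F)(F)F)cc3)n2)n2nc(SCc3ccc(Br)cc3)nc2n1` is the next to be tested. It carries 4-(trifluoromethyl)phenyl in place of naphthalen-1-yl on a saturated chain carbon bound to an aromatic nitrogen. Put another way, (naphthalen-1-yl)methyl becomes 4-(trifluoromethyl)benzyl.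

For the measured compounds named here, no measured step touches this place. The only one, an at least 6.1-fold higher number from compound 1 to compound 3 (0.78 log units; beyond the scatter), lies beyond the scatter, but it puts ethynyl in place of 4-fluorophenyl on a saturated chain carbon bound to a sulfur. That group stays untouched in the step to compound 4, so this step offers only weak guidance, and an aromatic ring remains on the changed chain. With so little to go on, no firm direction can be expected, and the expected change, a 1.1-fold higher number from compound 2 to compound 4 (0.03 log units; within the scatter), is estimated to stay within the scatter. For compound 4 the estimated value is 6000 nM, with an expected range from 2000 nM to 18000 nM.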

Compound 4, half-maximal inhibitory concentration: 5580 nM
Estimate against measurement, compound 4: 1.1-fold (0.03 log units) above; the range from low to high includes it.
By their numbers in this assay, from the lowest: compounds 4, 2 and 1 (each within the scatter of the next). At a limit, above all of these: compound 3.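

In this assay, the step at this position is a 1.0-fold lower number from compound 2 to compound 4 (0.01 log units; within the scatter) and lies within the usual scatter, so compound 2 and compound 4 count as level. For the compounds shown here, this is the first measured step at the saturated chain carbon bound to an aromatic nitrogen, and it shows that two quite different aromatic groups can sit there with no visible difference in this cell assay: naphthalen-1-yl has 2 six-membered aromatic rings of carbon only, whereas 4-(trifluoromethyl)phenyl has one such ring and 3 fluorine atoms, with 10 heavy atoms in each. Nothing measured in this set bears on why the two values stay level.

With only these two aromatic groups at this position, the compounds shown leave open whether the value would hold with a group that has no aromatic ring, such as a simple cyclohexyl, or with a carboxylic acid or an amine in place of trifluoromethyl. They also leave open whether a longer chain to the ring would give a number that differs beyond the scatter, and whether the same level result would hold if the 4-bromobenzyl group on the sulfur were replaced.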